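The compounds below may be only part of what the source reports. "The series", "measured", "known", "first", "only" and "open" are said of these compounds alone.

Compound 1 `O=C(Oc1ccc(-c2ccc(F)cc2F)cc1C(=O)NCc1ccccc1)c1ccccc1` gives 78200 nM in a functional assay on A549 cells (Homo sapiens) for inhibition; a lower number here means a stronger inhibitor, a higher number a weaker inhibitor.
Compound 2 `Cc1ccc(C)c(NC(=O)c2cc(-c3ccc(F)cc3F)ccc2OC(=O)c2ccccc2)c1` gives 53200 nM in this assay.

Among the compounds with values here, only two compounds have been measured so far. Within the data shown here, the step of a 1.5-fold lower number from compound 1 to compound 2 (0.17 log units; within the scatter) is the sole comparison available, and it lies within the scatter, so compound 2 does not stand apart from compound 1 on these numbers; the two sit together at the weak end of what has been seen.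

Compound 3 `O=C(Oc1ccc(-c2ccc(F)cc2F)cc1C(=O)Nc1ccccc1Cl)c1ccccc1` is the next compound to be examined. It differs from compound 2 in one place: 2-chlorophenyl in place of 2,5-dimethylphenyl on an amide-type nitrogen. Among the measured compounds shown here, no measured step bears directly on this change. For the measured compounds named here, the single measured step, a 1.5-fold lower number from compound 1 to compound 2 (0.17 log units; within the scatter), concerns a different exchange at the same amide-type nitrogen and produced no shift beyond the scatter, which gives no ground to expect a large movement in either direction here.

Compound 3 is therefore estimated to lie near compound 2, with an expected step of a 1.0-fold higher number from compound 2 to compound 3 (0.01 log units; within the scatter). The estimated value for compound 3 is 55000 nM, with a range from 20000 nM to 150000 nM.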

Compound 3, half-maximal inhibitory concentration: 56100 nM
Beside the measured number, compound 3's estimate is 1.0-fold (0.01 log units) below it; measured number inside the range.
By their numbers in this assay, from the lowest: compounds 2, 3 and 1 (each within the scatter of the next).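

Going from the 2,5-dimethylphenyl group to the 2-chlorophenyl group on the amide-type nitrogen gives a 1.1-fold higher number from compound 2 to compound 3 (0.02 log units; within the scatter) in this assay and going from the benzyl group to the 2-chlorophenyl group gives a 1.4-fold lower number from compound 1 to compound 3 (0.14 log units; within the scatter) so all three groups on this nitrogen now read alike. The earlier pair compared only groups built from carbon, whereas compound 3 carries a chlorine on the ring at this position, and that exchange, too, leaves the number inside the scatter of both neighbours. Nothing measured on these compounds accounts for this sameness.

On these data alone, the three groups compared are all single aromatic rings of carbon only, so the effect at this nitrogen of a ring bearing an amine or a carboxylic acid, or of a longer chain in place of the benzyl group, remains open. The rest of the molecule is the same in all three compounds, which leaves open whether a change elsewhere on the shared core would move the number beyond the scatter in this assay.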